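Ring nitrogen substituents in an mGlu5 negative modulator series

This account rests on a few compounds, and the source may have more. Where it says the series, first, only, none or still open, it means among the compounds named here.

Measured compounds:
compound 1 `O=C1CC(c2nc(-c3cccc(Cl)c3)no2)CN1c1cccc(Cl)c1` gives 1100 nM in an in vitro functional assay on HEK293-A cells for negative allosteric modulation of metabotropic glutamate receptor 5 (Homo sapiens), read by FLIPR and calcium flux; on this read-out higher numbers stand for weaker inhibition and lower numbers for stronger inhibition
compound 2 `CC(C)CN1CC(c2nc(-c3cccc(Cl)c3)no2)CC1=O` gives 920 nM in this assay
compound 3 `O=C1CC(c2nc(-c3cccc(Cl)c3)no2)CN1c1ccc(Cl)c(Cl)c1` gives > 10000 nM in this assay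

The value of compound 3 is a limit of this assay and not a number (the limit of > 10000 nM in this assay, at which 1 of the 3 values shown sits); compound 3 thus stands at the weak end of the three. Compound 4 `O=C1CC(c2nc(-c3cccc(Cl)c3)no2)CN1c1ccccc1Cl` is not yet measured; the change is 2-chlorophenyl in place of 3,4-dichlorophenyl on an amide-type nitrogen in a ring. For the measured compounds named here, the steps that bear on it are an at least 9.0-fold higher number from compound 1 to compound 3 (0.95 log units; beyond the scatter) and an at least 10-fold higher number from compound 2 to compound 3 (1.03 log units; beyond the scatter). Since removing the added chloro undoes the first of these, a lower number for compound 4 is expected, although the remaining chloro sits differently from that of compound 1. The estimated step is an at least 4.0-fold lower number from compound 3 to compound 4 (0.60 log units; beyond the scatter). Compound 4 is therefore expected near 2500 nM, between 700 nM and 10000 nM.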

Compound 4, half-maximal inhibitory concentration: 680 nM
Compound 4: the middle estimate sits 3.7-fold (0.57 log units) above what was measured; measured number outside the range, below it.
By their numbers in this assay, from the lowest: compounds 4, 2 and 1 (each within the scatter of the next). At a limit, above all of these: compound 3.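

Compound 4 shows that a chlorophenyl on the amide-type nitrogen can keep activity in this assay when the group is 2-chlorophenyl and not 3,4-dichlorophenyl, with an at least 14-fold lower number from compound 3 to compound 4 (1.16 log units; beyond the scatter) as the step. That step rests on a limit for compound 3 and not a number: the limit of > 10000 nM in this assay, at which 1 of the 4 values shown sits. Neither a 1.6-fold lower number from compound 1 to compound 4 (0.21 log units; within the scatter) nor a 1.4-fold lower number from compound 2 to compound 4 (0.13 log units; within the scatter) separates 2-chlorophenyl from 3-chlorophenyl or isobutyl.

On these data alone, whether 4-chlorophenyl alone matches 3,4-dichlorophenyl remains open. So does the effect of an amine or carboxylic acid on a longer chain at this nitrogen.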